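Fused nucleoside series: furan-3-yl for thiophen-3-yl

The compounds below may be only part of what the source reports. "The series", "measured", "known", "first", "only" and "open" are said of these compounds alone.

Measured so far:
compound 1 `COc1nc(N)nc2c1c(-c1cc3ccccc3o1)cn2[C@@H]1O[C@H](CO)[C@@H](O)[C@H]1O` — in a functional assay on A549 cells (Homo sapiens), read by MTT assay, with a stated time of 72 h (on this read-out higher numbers stand for weaker inhibition and lower numbers for stronger inhibition), compound 1 gives > 20000 nM, a limit of the assay.
compound 2 `Cc1ncnc2c1c(-c1cccs1)cn2[C@@H]1O[C@H](CO)[C@@H](O)[C@H]1O` — in this assay compound 2 gives > 20000 nM, a limit of the assay.
compound 3 `O=c1[nH]cnc2c1c(-c1ccsc1)cn2[C@@H]1O[C@H](CO)[C@@H](O)[C@H]1O` — in this assay compound 3 gives > 20000 nM, a limit of the assay.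

Compound 3 stands nowhere distinct on these numbers: its value is a limit, and the two other values shown are limits as well. Among the measured compounds shown here, all three sit at the limit of > 20000 nM in this assay, at which 3 of the 3 values shown sit, so no step between measured compounds can be read, and no pattern can be claimed from them.

Compound 4 `O=c1[nH]cnc2c1c(-c1ccoc1)cn2[C@@H]1O[C@H](CO)[C@@H](O)[C@H]1O` is not yet measured. Against compound 3 it differs in one place: furan-3-yl in place of thiophen-3-yl on an aromatic carbon. With every measured compound at the same limit, no direction of change is indicated by the data; the expectation for the step is none beyond the scatter, with compound 4 most likely also reported as a limit rather than a number.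

The estimate for compound 4 in this assay is 40000 nM, with a range from 15000 nM to 150000 nM, which corresponds to an expected step that the limit leaves unreadable from compound 3 to compound 4.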

Compound 4, half-maximal inhibitory concentration: > 20000 nM
Compound 4: only a limit was reported (the forecaster's own chance of this, stated with the estimate: 85%); the middle value does not contradict the limit.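

No step can be read between compound 3 and compound 4, since in this assay both are reported only as limits, and the furan-3-yl for thiophen-3-yl exchange therefore stays unresolved: the limit of > 20000 nM in this assay, at which 4 of the 4 values shown sit.

The compounds shown leave open whether any change on the shared core gives a measurable value in this assay.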